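Adding a Chloro Group to Compound 2

The source may hold more compounds than are shown below. What is called first, only, known or untested is meant among the compounds shown, and "the series" means these compounds.

In a functional assay on Bel-7402 cells (Homo sapiens) for inhibition, read by MTT assay, with a stated time of 24 h, tested at 10 ug/mL (a higher number here means more inhibition of growth at the concentration tested, a lower number less inhibition of growth), compound 1 `CC(=O)SCCC(CCCCC(=O)O)SC(C)=O` gives 9.22%. Compound 2 `CC(=O)SCCC(CCCCC(=O)Nc1ccccc1)SC(C)=O`, which has an anilino amide in place of the free acid on the same core, is reported as "not active" (no number reported). For the measured compounds named here, compound 2 therefore stands without a number, and no measured step links it to compound 1.

One further structure, compound 3 `CC(=O)SCCC(CCCCC(=O)Nc1ccccc1Cl)SC(C)=O`, remains to be tested. Its change is a single one: chloro in place of hydrogen on an aromatic carbon. The phenyl of compound 2 thus becomes the 2-chlorophenyl of compound 3.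

Going by the values given here, no measured step is available as a guide, so no change beyond the usual scatter is expected in this assay. That expectation rests on the low reading of compound 1 at 9.22% and on compound 2 at "not active" (no number reported). Compound 3 is estimated at 8%, with an expected range of 0% to 20%.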

Compound 3, percent growth inhibition at one concentration: 3.09%
Compound 3: the middle estimate sits 4.9 percentage points above what was measured; measured number inside the range.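

From the compounds shown here alone, with compound 3, the aromatic carbon ortho to a large group gives a number in this assay, as compound 3 reads 3.09%, but compound 2 has no number, so the step from the phenyl to the 2-chlorophenyl cannot be read and the size of any effect of chloro in place of hydrogen remains unknown. The new reading does connect the anilide series to the free acid: with (2-chlorophenyl)amino in place of hydroxy on the carbonyl carbon, the result is a number 6.1 percentage points lower from compound 1 to compound 3 (within the scatter), a step that lies within the usual scatter, so these two compounds cannot be told apart in this assay. No supporting information bears on this result, and the reading stands without an explanation.

The compounds shown leave open whether a fluoro, bromo or methoxy group on the same aromatic carbon would read differently from chloro in this assay. They also leave open what a free thiol in place of the acetylthio groups, or a longer chain between the core and the carbonyl, would give at the single concentration tested.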